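Terthiophene series: replacing the terminal amine with an azide

The source may report more compounds than this note shows. Statements on the series, on what has been measured and on what is new or still open speak of the compounds shown alone.

Among the compounds with values here, compound 1, `NCCCCc1ccc(-c2ccc(-c3cccs3)s2)s1`, and compound 2, `NCCCCc1ccc(-c2ccc(-c3ccc(CCCCN)s3)s2)s1`, are the two measured members. In an ADME assay on MDCK cells (Canis lupus familiaris) for cytotoxicity, read by MTT assay, with a stated time of 2 days (a lower number here means that less compound is tolerated, a higher number that more compound is tolerated), compound 1 gives 13300 nM, and in the same assay compound 2 gives 13000 nM. Compound 1 thus holds the highest of the two numbers, with compound 2 nearest to it, the two values within the scatter of each other. Within the data shown here, the only measured step, a 1.0-fold lower number from compound 1 to compound 2 (0.01 log units; within the scatter), shows that adding a second 4-aminobutyl chain to the core of compound 1 leaves the number where it was.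

Compound 3, `[N-]=[N+]=NCCCc1ccc(-c2ccc(-c3cccs3)s2)s1`, is not yet measured in this assay. It differs from compound 1 by azido in place of aminomethyl on a saturated chain carbon, three bonds along the chain from an aromatic carbon. Among the measured compounds shown here, no measured step touches the chain end itself; the one step known, from compound 1 to compound 2, was within the scatter and concerned a different position. On that basis no step beyond the scatter is expected for compound 3, a change estimated as a 1.0-fold lower number from compound 1 to compound 3 (0.01 log units; within the scatter). The value for compound 3 is therefore estimated at 13000 nM, with an expected range from 5000 nM to 35000 nM.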

Compound 3, half-maximal cytotoxic concentration: > 200000 nM
Compound 3 gave a limit, no number (the forecaster's own chance of this, stated with the estimate: 10%); at least 15-fold (1.18 log units) between middle value and limit.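

Within the data shown here, the chain end is the first place where a change moves the number: in this assay the step is an at least 15-fold higher number from compound 1 to compound 3 (1.17 log units; beyond the scatter), whereas the earlier step, a 1.0-fold lower number from compound 1 to compound 2 (0.01 log units; within the scatter), changed a different position and stayed within the scatter. The two compounds carrying 4-aminobutyl lie within the scatter of each other, and only compound 3, with 3-azidopropyl in its place, departs from them, so in these three compounds the group at the chain end counts for far more than a second chain on the core. Compound 3 gives a limit and not a number, so the full size of the step stays open: the limit of > 200000 nM in this assay, at which 1 of the 3 values shown sits.

The compounds shown do not separate the loss of the amine from the gain of the azido group, and a hydroxyl or a plain alkyl end on the same chain would tell these two apart. Also open, from the compounds shown here alone, is whether the azido counterpart of compound 2 would follow compound 3, and whether a longer chain carrying the azido group would keep the same step.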